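Working notes: an aryl swap on the amide nitrogen

The source may report more compounds than this note shows. Statements on the series, on what has been measured and on what is new or still open speak of the compounds shown alone.

Measured in a functional assay on MIA PaCa-2 cells (Homo sapiens) for inhibition, read by MTT assay; a lower number here means a stronger inhibitor, a higher number a weaker inhibitor:
- compound 1 `Cc1cc(C)nc(NS(=O)(=O)c2ccc(Nc3ncc4cc(C(=O)N(C)C)n(C5CCCC5)c4n3)cc2)n1` gives 8250 nM
- compound 2 `COc1cccc(NC(=O)c2cc3cnc(Nc4ccc(N5CCNCC5)cn4)nc3n2C2CCCC2)c1` gives 2650 nM

Compound 2 holds the lower number of the two, and its gap to compound 1 lies beyond the scatter. In compound 3 `O=C(Nc1ccccc1C(F)(F)F)c1cc2cnc(Nc3ccc(N4CCNCC4)cn3)nc2n1C1CCCC1`, 2-(trifluoromethyl)phenyl stands in place of 3-methoxyphenyl on an amide-type nitrogen (2-(trifluoromethyl)phenyl in place of 3-methoxyphenyl on an amide-type nitrogen). Among the compounds with values here, no measured step shows this change, so the expectation rests on the structural change alone. The step expected in this assay is a 1.3-fold higher number from compound 2 to compound 3 (0.12 log units; within the scatter), small and towards a weaker number, possibly within the scatter. The estimated value for compound 3 is 3500 nM, with an expected range from 1200 nM to 10000 nM.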

Compound 3, half-maximal inhibitory concentration: 3160 nM
Compound 3: middle estimate off by 1.1-fold (0.04 log units), on the high side; the measured number falls inside the stated range.
By their numbers in this assay, from the lowest: compounds 2 and 3 (each within the scatter of the next); then compound 1.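

On the amide-type nitrogen, 2-(trifluoromethyl)phenyl in place of 3-methoxyphenyl gives a 1.2-fold higher number from compound 2 to compound 3 (0.08 log units; within the scatter) in this assay. This first step at the position therefore separates the two aryl groups by no more than the scatter, even though the hydrogen-bond acceptor counted in 3-methoxyphenyl is absent from the group that enters. Nothing available accounts for this result.

Open, from the compounds shown here alone, is whether this position keeps its number with a non-aryl group, such as cyclohexyl, or with a carboxylic acid on the phenyl ring.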